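One Inverted Ring Centre, From Compound 1 to Compound 4

The compounds below may be only part of what the source reports. "The series", "measured", "known", "first", "only" and "open" are said of these compounds alone.

Compound 1, with the structure `CCC[C@@H]1O[C@H](COCc2ccccc2)[C@H](OCc2ccccc2)[C@H](OCc2ccccc2)[C@H]1O`, is tested in a functional assay on HL-60 cells (Homo sapiens) for antiproliferative activity, read by MTT assay; a higher number here means a weaker inhibitor, a lower number a stronger inhibitor. Here compound 1 is recorded as "not active" (no number reported), so no single number stands for it; compound 2, `C=CC[C@@H]1O[C@H](COCc2ccccc2)[C@@H](OCc2ccccc2)[C@H](OCc2ccccc2)[C@@H]1O`, is likewise recorded in this assay as "not active" (no number reported), and compound 3, `O[C@@H]1[C@@H](O)[C@H](Cc2ccccc2)O[C@H](COCc2ccccc2)[C@H]1OCc1ccccc1`, is the only one with a number, giving 26600 nM in this assay. Compound 4, `CCC[C@@H]1O[C@H](COCc2ccccc2)[C@@H](OCc2ccccc2)[C@H](OCc2ccccc2)[C@H]1O`, is not yet measured. It differs from compound 1 in this way: the two compounds have the same atoms and bonds and differ only in configuration as drawn: 1 of 5 stereo elements differ; a stereocentre at a saturated ring carbon is drawn S in compound 1 and R in compound 4. Within the data shown here, nothing measured shows how a change in configuration alone shifts potency here, so no step in this assay beyond the scatter is assumed, and compound 4 is expected to stay weak, as compound 1 is. Compound 4 is estimated at 50000 nM in this assay, within 15000 nM to 200000 nM.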

Compound 4, half-maximal inhibitory concentration: 11700 nM
Beside the measured number, compound 4's estimate is 4.3-fold (0.63 log units) above it; the whole stated range lies above it.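

Among these compounds, with no single number for compound 1, no step to compound 4 can be read from this assay. The compounds shown leave open how far inverting that one ring centre alone shifts potency.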